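A few compounds are considered here, and "the series" means these few. Any claim that something is new, unique, unknown or untested is made for them only; others in the source may bear on it.

Working notes on the series. Compound 1 is `COc1cccc([C@@H]2OC[C@H]([C@@H](O)c3ccc(OC)c(OC)c3)C[C@H]2C/C=C/c2ccc(OC)c(OC)c2)c1`, compound 2 is `COc1ccc(/C=C/C[C@@H]2C[C@@H]([C@@H](O)c3ccc(OC)c(OC)c3)CO[C@H]2c2ccccc2)cc1OC`, compound 3 is `COc1ccc(/C=C/C[C@H]2C[C@@H]([C@@H](O)c3ccc(OC)c(OC)c3)CO[C@@H]2c2ccc(OC)c(OC)c2)cc1OC`, and the unmeasured compound 4 is `COc1cccc(/C=C/C[C@H]2C[C@@H]([C@@H](O)c3ccc(OC)c(OC)c3)CO[C@@H]2c2ccc(OC)c(OC)c2)c1`. In a functional assay on HeLa cells (Homo sapiens) for cytotoxicity, read by WST assay, with a stated time of 48 h (on this read-out higher numbers stand for weaker inhibition and lower numbers for stronger inhibition), compound 1 gives 30100 nM. In this assay compound 2 gives 16100 nM, and compound 3 gives 23800 nM. All three measured values lie within the usual scatter of one another, so no order among them can be read from these numbers.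

The change from compound 1 to compound 2 is hydrogen in place of methoxy on an aromatic carbon, and it made a 1.9-fold lower number from compound 1 to compound 2 (0.27 log units; within the scatter). The difference between the core of compound 1 and the core of compound 3 is not broken down here; their two values show only that they sit within the scatter of each other.

The change from compound 3 to compound 4 is hydrogen in place of methoxy on an aromatic carbon. It is the same kind of change as that from compound 1 to compound 2, not the same: in compound 3 the methoxy leaves a place ortho to a methoxy group and para to a large group, whereas in compound 1 it leaves a place meta to a large group, so the ring that carries the change is a different one.

From compound 3 to compound 4 a step of a 1.3-fold lower number from compound 3 to compound 4 (0.12 log units; within the scatter) is expected in this assay, because the same kind of change gave a 1.9-fold lower number from compound 1 to compound 2 (0.27 log units; within the scatter). For compound 4 the expected value in this assay is 18000 nM, with the estimate spanning from 8000 nM to 40000 nM.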

Compound 4, half-maximal inhibitory concentration: 14000 nM
The estimate for compound 4 lay 1.3-fold (0.11 log units) above the measured number; measured number inside the range.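

In this assay, hydrogen in place of methoxy on the aromatic ring of the side chain, turning 2-(3,4-dimethoxyphenyl)ethenyl into 2-(3-methoxyphenyl)ethenyl, gives a 1.7-fold lower number from compound 3 to compound 4 (0.23 log units; within the scatter). Set beside the earlier case, the two steps cannot be told apart: the same change on two cores in this assay, a 1.9-fold lower number (0.27 log units; within the scatter) from compound 1 to compound 2 and a 1.7-fold lower number (0.23 log units; within the scatter) from compound 3 to compound 4, 1.1-fold (0.04 log units) apart, within the scatter of two such steps. Across these two pairs, the replacement therefore carries from one core to the other without a detectable difference in step size; but each step lies within the scatter on its own, so the agreement does not show that the replacement has a real effect of any size on either core, and two pairs, with the change on a different ring in each, do not establish a rule for other cores in the series.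

Still open, going by these compounds, is whether a group other than hydrogen in place of that methoxy, such as a hydroxy group, a fluorine atom or an amine, would move the number beyond the scatter of these values. Also open is whether a larger edit elsewhere, such as a carboxylic acid on the aromatic ring or a longer chain in place of the side chain, would separate any of these compounds in this assay.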